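Capping the Ring Nitrogen of Compound 2

A few compounds are considered here, and "the series" means these few. Any claim that something is new, unique, unknown or untested is made for them only; others in the source may bear on it.

Compound 1, `CC1(C)[C@H]2CC[C@]1(C)[C@H](OC(=O)CN1CCCCC1)C2`, gives 138000 nM in an ADME assay on MDCK cells (Canis lupus familiaris) for cytotoxicity, read by MTT assay, with a stated time of 48 h; on this read-out higher numbers stand for lower toxicity in this test and lower numbers for higher toxicity in this test.
Compound 2, `CC1(C)[C@H]2CC[C@]1(C)[C@H](OC(=O)CCN1CCNCC1)C2`, gives 12600 nM in this assay.

Of these two numbers, compound 2 holds the lowest, so it is the more toxic in this assay; its nearest neighbour is compound 1, separated by the step of an 11-fold lower number from compound 1 to compound 2 (1.04 log units; beyond the scatter). Compound 3, `CCOC(=O)N1CCN(CCC(=O)O[C@@H]2C[C@@H]3CC[C@@]2(C)C3(C)C)CC1`, is built from compound 2 by one change: ethoxycarbonyl in place of hydrogen on an amine nitrogen in a ring. Within the data shown here, the only measured step, an 11-fold lower number from compound 1 to compound 2 (1.04 log units; beyond the scatter), concerns a different alteration, the exchange of one ring amine for another, and so does not directly show what capping a ring nitrogen does. Among the measured compounds shown here, with no measured pair separating a free ring nitrogen from a substituted one, the expectation is a step within the scatter, leaning if anything towards a slightly higher number; the step from compound 2 to compound 3 is estimated as a 1.6-fold higher number from compound 2 to compound 3 (0.20 log units; within the scatter). Compound 3 is therefore expected to give about 20000 nM in this assay, within a range from 6000 nM to 70000 nM.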

Compound 3, half-maximal cytotoxic concentration: 150000 nM
Beside the measured number, compound 3's estimate is 7.5-fold (0.88 log units) below it; the measured number lies above the stated range.
By their numbers in this assay, from the lowest: compound 2; then compounds 1 and 3 (each within the scatter of the next).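

In this assay, ethoxycarbonyl on the amine nitrogen in the ring gives a 12-fold higher number from compound 2 to compound 3 (1.08 log units; beyond the scatter) and so marks this nitrogen as a place where one substituent moves the read-out strongly, towards lower toxicity in this test. The earlier step exchanged one ring amine and its chain for another, so it could not show what a group on this nitrogen does while the rest of the molecule stays fixed. Nothing available here accounts for the size of this rise.

The compounds shown leave open whether the rise belongs to ethoxycarbonyl itself or would follow from other groups on the same nitrogen. A methyl, an acetyl or a benzyl group there would help separate these two readings.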